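Replacing bromo with methoxy on compound 1

The source may hold more compounds than are shown below. What is called first, only, known or untested is meant among the compounds shown, and "the series" means these compounds.

Compound 1 `CNC(=O)c1cc(Oc2ccc(NC(=O)c3cc(-c4ccc(Br)cc4)ncn3)cc2)ccn1`: > 100000 nM
Compound 2 `CNC(=O)c1cc(Oc2ccc(NC(=O)c3nccc(-c4ccc([N+](=O)[O-])cc4)n3)cc2)ccn1`: > 100000 nM
Compound 3 `CNC(=O)c1cc(Oc2ccc(NC(=O)c3cc(-c4ccc(Br)cc4)ncn3)cc2F)ccn1`: > 100000 nM

In a functional assay on MCF7 cells (Homo sapiens) for cytotoxicity, read by MTT assay, with a stated time of 72 h (a lower number here means a stronger inhibitor, a higher number a weaker inhibitor), compound 1 gives > 100000 nM, which is a limit and not a number. It has no measured neighbour to be ranked against, since the evidence reads (the limit of > 100000 nM in this assay, at which 3 of the 3 values shown sit). Compound 4 `CNC(=O)c1cc(Oc2ccc(NC(=O)c3cc(-c4ccc(OC)cc4)ncn3)cc2)ccn1` keeps the core of compound 1 and differs in one place: methoxy in place of bromo on an aromatic carbon. This is methoxy in place of bromo on an aromatic carbon. Going by the values given here, the one measured step, a step that the two limits leave unreadable from compound 1 to compound 3, is fluoro in place of hydrogen on an aromatic carbon, so it offers no size to carry over. No step beyond the scatter is therefore expected in this assay. The expected step is a number no higher from compound 1 to compound 4 (the limit leaves the size open). Compound 4 is estimated at 100000 nM, with an expected range of 30000 nM to 200000 nM.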

Compound 4, half-maximal inhibitory concentration: 29200 nM
Beside the measured number, compound 4's estimate is 3.4-fold (0.53 log units) above it; measured number outside the range, below it.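

In this assay, going by these compounds alone, going from 4-bromophenyl to 4-methoxyphenyl gives an at least 3.4-fold lower number from compound 1 to compound 4 (0.53 log units; beyond the scatter), the first sign that a change at this position can shift the read-out. Compound 4 is the only compound shown that gives a number and not a limit: the limit of > 100000 nM in this assay, at which 3 of the 4 values shown sit. Going by these compounds, the true size of the step remains open, as compound 1 holds only a limit.

On these data alone, it is open whether an amine, a hydroxyl or a longer chain such as ethoxy at this position would lower the number further. As far as these compounds go, it is also open whether methoxy would have a similar effect on compound 3.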